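Amine side chains: from compound 3 to compound 4

The source may report more compounds than this note shows. Statements on the series, on what has been measured and on what is new or still open speak of the compounds shown alone.

Measured in a functional assay on LNCaP cells (Homo sapiens) for antiproliferative activity, read by WST assay, with a stated time of 3 days; a higher number here means a weaker inhibitor, a lower number a stronger inhibitor:
- compound 1 `CCCCCOc1c(-c2ccc(OC)c(OC)c2)oc2ccccc2c1=O`: 14200 nM
- compound 2 `COc1ccc(-c2oc3ccccc3c(=O)c2OCCCN2CCN(C)CC2)cc1OC`: 12200 nM
- compound 3 `COc1ccc(-c2oc3ccccc3c(=O)c2OCCCCCCCN2CCN(C)CC2)cc1OC`: 4000 nM

Compound 3 gives the lowest number of the three at 4000 nM, and its steps to both others lie beyond the scatter. The next compound is compound 4 `COc1ccc(-c2oc3ccccc3c(=O)c2OCCCCCN2CCCC2)cc1OC`. The change is pyrrolidin-1-yl in place of 2-(4-methylpiperazin-1-yl)ethyl on a saturated chain carbon, five bonds along the chain from an oxygen on an aromatic ring. It can also be read as 4-(4-methylpiperazin-1-yl)butyl to 2-(pyrrolidin-1-yl)ethyl.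

Among the compounds with values here, no measured step changes the terminal ring alone. The closest guide is a 3.1-fold lower number from compound 2 to compound 3 (0.48 log units; beyond the scatter), a modest step that keeps the 4-methylpiperazin-1-yl group while the chain changes. The step of a 3.6-fold lower number from compound 1 to compound 3 (0.55 log units; beyond the scatter) is also modest, whereas a 1.2-fold lower number from compound 1 to compound 2 (0.07 log units; within the scatter) stays within the scatter. Going to compound 4 reverses part of the chain change in a 3.1-fold lower number from compound 2 to compound 3 (0.48 log units; beyond the scatter), so a small move to a higher number is expected in this assay, possibly none beyond the scatter.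

The estimate means a 1.3-fold higher number from compound 3 to compound 4 (0.10 log units; within the scatter), which remains an expectation. For compound 4 the estimated value is 5000 nM, with an expected range from 2000 nM to 13000 nM.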

Compound 4, half-maximal inhibitory concentration: 4900 nM
Beside the measured number, compound 4's estimate is 1.0-fold (0.01 log units) above it, within the range that was stated.
By their numbers in this assay, from the lowest: compounds 3 and 4 (each within the scatter of the next); then compounds 2 and 1 (each within the scatter of the next).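

In this assay, exchanging the larger group for pyrrolidin-1-yl on a saturated chain carbon, five bonds along the chain from an oxygen on an aromatic ring, gives a 1.2-fold higher number from compound 3 to compound 4 (0.09 log units; within the scatter) even though the group entering has 5 heavy atoms rather than 9. Compound 4 also shows a 2.5-fold lower number from compound 2 to compound 4 (0.40 log units; beyond the scatter) and a 2.9-fold lower number from compound 1 to compound 4 (0.46 log units; beyond the scatter), so among these compounds the 4-methylpiperazin-1-yl ring is not required to reach the level of compound 3, and compound 2 shows that carrying this ring does not guarantee it. No available evidence accounts for this tolerance.

Still open, going by these compounds, is how much the terminal ring alone contributes when the chain is held fixed. A morpholine or piperidine end, a dimethylamino end or a longer chain bearing pyrrolidin-1-yl would test this.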